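From pyrimidin-2-yl to 1H-pyrazol-1-yl on the shared core

The source may hold more compounds than are shown below. What is called first, only, known or untested is meant among the compounds shown, and "the series" means these compounds.

In an ADME assay on Caco-2 cells (Homo sapiens) for permeability, read by LC-MS, in the apical to basolateral direction, with a stated time of 90 min (on this read-out higher numbers stand for higher permeability and lower numbers for lower permeability), compound 1 (`O=C(NNS(=O)(=O)c1ccccc1F)c1cc(F)cc(-c2ccccn2)c1`) gives 60 10^-6 cm/s and compound 2 (`Cc1cc(-c2ncccn2)cc(C(=O)NNS(=O)(=O)c2ccccc2)c1F`) gives 77 10^-6 cm/s on the same scale. These two numbers lie within the usual scatter of each other, so compound 2 cannot be separated from compound 1. For the measured compounds named here, compound 3 (`Cc1cc(-n2cccn2)cc(C(=O)NNS(=O)(=O)c2ccccc2)c1F`) has 1H-pyrazol-1-yl in place of pyrimidin-2-yl on an aromatic carbon and no measured step shows this change. In this assay no step beyond the scatter is expected, and the expected 1.1-fold lower number from compound 2 to compound 3 (0.04 log units; within the scatter) has no firm direction. The estimate for compound 3 is 70 10^-6 cm/s and the range of 35 10^-6 cm/s to 130 10^-6 cm/s is expected to hold it.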

Compound 3, apparent permeability: 48 10^-6 cm/s
Compound 3: the middle estimate sits 1.5-fold (0.16 log units) above what was measured; the range from low to high includes it.
By their numbers in this assay, from the lowest: compounds 3, 1 and 2 (each within the scatter of the next).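

In this assay, for the compounds shown here, 1H-pyrazol-1-yl in place of pyrimidin-2-yl, on an aromatic carbon para to a fluoro group, gives a 1.6-fold lower number from compound 2 to compound 3 (0.21 log units; within the scatter), the first measured step at this position. A five-membered aromatic ring can therefore stand where a six-membered one stood without a step beyond the scatter. No measured evidence bears on the reason for this result. As far as these compounds go, whether an amine or a carboxylic acid on this aromatic carbon would move the number beyond the scatter remains open.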